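Methoxy Added to the Core of a Vinyl Sulfone Indole

The compounds below may be only part of what the source reports. "The series", "measured", "known", "first", "only" and "open" are said of these compounds alone.

Three compounds sharing an indole-based core were tested in a functional assay on LOX IMVI cells (Homo sapiens) for inhibition, read by sulforhodamine B assay, with a stated time of 48 h; on this read-out lower numbers stand for stronger inhibition of growth and higher numbers for weaker inhibition of growth. Compound 1 `COc1ccc(-c2[nH]c3ccccc3c2/C=C(\C#N)S(=O)(=O)c2ccccc2)cc1` gives 1300 nM in this assay, the lowest of the three numbers. Compound 2 `COc1ccc2[nH]c(-c3ccccc3)c(C=C(C#N)C#N)c2c1` gives 4900 nM, and compound 3 `CCOC(=O)C(=Cc1c(-c2ccccc2)[nH]c2ccccc12)C(=O)OCC` gives 5600 nM; both of these values lie beyond the usual scatter from compound 1, so compound 1 stands as the most potent of the three measured compounds. Going by the values given here, no single-change step between any two of these measured compounds is available, so each pair can only be read by what its two values show.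

Compound 4 `COc1ccc(-c2[nH]c3ccc(OC)cc3c2/C=C(\C#N)S(=O)(=O)c2ccccc2)cc1` has not yet been measured. It differs from compound 1 by methoxy in place of hydrogen on an aromatic carbon. Among the compounds with values here, no measured pair isolates this change, so the expectation is a small step, in either direction, not beyond the scatter; the step from compound 1 to compound 4 is estimated as a 1.2-fold higher number from compound 1 to compound 4 (0.06 log units; within the scatter). Compound 4 is therefore expected to give about 1500 nM in this assay, with a range from 600 nM to 4000 nM.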

Compound 4, concentration for 50% growth inhibition: 1200 nM
The estimate for compound 4 lay 1.3-fold (0.10 log units) above the measured number; the range from low to high includes it.
By their numbers in this assay, from the lowest: compounds 4 and 1 (each within the scatter of the next); then compounds 2 and 3 (each within the scatter of the next).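

In this assay, going by these compounds alone, methoxy in place of hydrogen on an aromatic carbon gives a 1.1-fold lower number from compound 1 to compound 4 (0.03 log units; within the scatter), the first single change that can be read in this set. It shows that this position, meta to a fused ring and para to a fused ring, accepts a methoxy with no shift in the number beyond the scatter, which the three earlier compounds, none of them one change apart, could not show. Nothing available explains why the number holds at this position.

The compounds shown leave open whether an amine, a carboxylic acid or a longer chain such as butoxy on the same carbon would also stay within the scatter of compound 1. They also leave open whether hydrogen in place of the methoxy on the core of compound 2 would move its number.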